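The compounds below may be only part of what the source reports. "The series", "measured", "known", "first", "only" and "open" are said of these compounds alone.

Of the compounds shown here, three built on a shared core have been tested in a functional assay for antagonist activity at corticotropin-releasing factor receptor 1 (Rattus norvegicus); a lower number here means a stronger inhibitor, a higher number a weaker inhibitor. Compound 1 `COc1ccc(-c2ncnc3c2nc(C)c(=O)n3C(C2CC2)C2CC2)c(C)c1` gives 37 nM, compound 2 `CC[C@H](C1CC1)n1c(=O)c(C)nc2c(-c3cc(F)c(OC)cc3Cl)ccnc21` gives 1.7 nM, and compound 3 `CC[C@H](C1CC1)n1c(=O)c(C)nc2c(-c3cc(Cl)c(OC)cc3C)ccnc21` gives 4.5 nM. Compound 3 stands second highest of the three numbers, beyond the scatter from both compound 2 and compound 1. Compound 4 `CC[C@H](C1CC1)n1c(=O)c(C)nc2c(-c3cc(F)c(OC)cc3C)ccnc21` is not yet measured and differs from compound 3 in one place: fluoro in place of chloro on an aromatic carbon. Within the data shown here, no measured pair shows exactly this change. Compound 2 also carries fluoro in place of chloro, though with a different second group, and gives 1.7 nM, so a modest lowering is expected. The step from compound 3 to compound 4 in this assay is estimated at a 1.5-fold lower number from compound 3 to compound 4 (0.18 log units; within the scatter). Compound 4 is expected to give about 3 nM, likely between 1 nM and 10 nM.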

Compound 4, half-maximal inhibitory concentration: 9.4 nM
Beside the measured number, compound 4's estimate is 3.1-fold (0.50 log units) below it; the measured number falls inside the stated range.
By their numbers in this assay, from the lowest: compound 2; then compound 3; then compound 4; then compound 1.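

On this aromatic carbon, ortho to a methoxy group, chloro gives the lower number: replacing it with fluoro brings a 2.1-fold higher number from compound 3 to compound 4 (0.32 log units; beyond the scatter) in this assay. Fluoro alone therefore does not account for the low number of compound 2, since with fluoro kept, methyl in place of chloro at the other changed carbon brings a 5.5-fold higher number from compound 2 to compound 4 (0.74 log units; beyond the scatter). Nothing at hand explains either step. The compounds shown leave open how a bromo group or a nitrile would fare at this position, and whether chloro here would still give the lower number when the other carbon carries chloro.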